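The compounds below may be only part of what the source reports. "The series", "measured", "known", "first", "only" and "open" are said of these compounds alone.

Measured so far in an ADME assay on Vero cells (Chlorocebus sabaeus) for cytotoxicity, read by MTT assay, with a stated time of 24 h; a lower number here means that less compound is tolerated, a higher number that more compound is tolerated:

Compound 1 `COc1ccc(Cn2c(SC(C)C(=O)Nc3ccc(C)cc3Cl)nc3ccccc32)cc1` gives > 75000 nM, which is a limit of this assay and not a number.

Compound 2 `Cc1ccc(NC(=O)C(C)Sc2nc3ccccc3n2Cc2ccccc2)c(Cl)c1` gives > 75000 nM, again a limit.

Compound 3 `COc1ccc(-n2c(SC(C)C(=O)Nc3ncc(C(F)(F)F)cc3Cl)nc3ccccc32)cc1` gives 9200 nM.

For the measured compounds named here, compound 3 is therefore the only compound of the three with a number; the other two sit at the limit of > 75000 nM in this assay, at which 2 of the 3 values shown sit. Going by the values given here, the one step between measured compounds, a step that the two limits leave unreadable from compound 1 to compound 2, runs from one limit to another and its size cannot be read.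

Compound 4 `COc1ccc(-n2c(SC(C)C(=O)Nc3ncc(C)cc3Cl)nc3ccccc32)cc1` differs from compound 3 by methyl in place of trifluoromethyl on an aromatic carbon. Among the compounds with values here, no measured step bears on this change: the only step on record concerns a methoxy group on a different part of the molecule, and it is unreadable. The expectation for compound 4 can therefore rest on nothing beyond the value of compound 3 itself, and the step from compound 3 to compound 4 is expected to be a 1.6-fold higher number from compound 3 to compound 4 (0.21 log units; within the scatter), with no direction that the data would support. Compound 4 is thus estimated at 15000 nM, in a range from 4000 nM to 60000 nM.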

Compound 4, half-maximal cytotoxic concentration: 880 nM
The estimate for compound 4 lay 17-fold (1.23 log units) above the measured number, outside the stated range (below it).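

In this assay, the change from 3-chloro-5-(trifluoromethyl)pyridin-2-yl to 3-chloro-5-methylpyridin-2-yl gives a 10-fold lower number from compound 3 to compound 4 (1.02 log units; beyond the scatter) and so marks methyl as the less tolerated of the two groups in this pair. For the compounds shown here, this is the first step that can be read, as the one earlier step runs between two limits and cannot be read; it shows that the group on this aromatic carbon, para to a large group, can move the number well beyond the scatter. Nothing measured here bears on why the step has this size.

As far as these compounds go, only trifluoromethyl and methyl are compared on this carbon, so it stays open where a nitrile, an amine or a carboxylic acid in the same place would fall. From the compounds shown here alone, whether the step keeps its size on a different core is also open, since it rests on this single pair.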